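The source may hold more compounds than are shown below. What is called first, only, known or untested is meant among the compounds shown, and "the series" means these compounds.

Measured compounds in an assay on CHO cells for displacement of a labelled ligand from adenosine receptor A1 (Homo sapiens), read by scintillation counting, with a stated time of 1 h, tested at 1 uM; on this read-out higher numbers stand for more inhibition at the one concentration tested (going by the name of the read-out) and lower numbers for less inhibition:
compound 1 `COc1ccc(-c2cnc(N)nc2-c2ccccc2)cc1` gives 56%
compound 2 `Nc1ncc(-c2ccccc2)c(-c2ccco2)n1` gives 26%
compound 3 `CC(C)CC(=O)Nc1ncc(-c2cccc(Cl)c2)c(-c2ccccc2)n1` gives 56%

Compound 3 stands level with compound 1 at the digits shown, the two together the highest of the three numbers, within the scatter of each other. The furthest is compound 2, a lower number, beyond the scatter. Among the measured compounds shown here, no single-change pair among the measured compounds exists, so the size of any one change is unknown here.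

Compound 4 `Clc1cccc(-c2cnc(NCc3ccccc3)nc2-c2ccccc2)c1` is the next compound, not yet measured. It differs from compound 3 in one place: benzyl in place of isobutylcarbonyl on a nitrogen on an aromatic ring

For the measured compounds named here, with no measured step to lean on, the expectation is a step of a number 6 percentage points lower from compound 3 to compound 4 (within the scatter) of no size beyond the scatter, in either direction. Compound 4 is estimated at 50%, range 25% to 75%.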

Compound 4, a percentage reported as inhibition, at one concentration (the size of the read-out at that concentration, not a potency): 16%
Compound 4: the middle estimate sits 34 percentage points above what was measured; measured number below the stated range.
By their numbers in this assay, from the lowest: compounds 4 and 2 (each within the scatter of the next); then compounds 1 and 3 (each within the scatter of the next).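

In this assay, benzyl in place of isobutylcarbonyl on a nitrogen on an aromatic ring brings a number 40 percentage points lower from compound 3 to compound 4 (beyond the scatter), so this position is sensitive to the group it carries. The change removes the carbonyl and its hydrogen-bond acceptor and adds a six-membered aromatic ring, and this single step cannot separate those differences. Nothing available explains the step.

Open, as far as these compounds go, is whether benzoyl on this nitrogen, which pairs a carbonyl with an aromatic ring, would stay nearer compound 3 or compound 4. A longer acyl chain would show how far the isobutylcarbonyl can be extended.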